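Adding 4-chlorophenyl to the carboxymethyl compound

The source may hold more compounds than are shown below. What is called first, only, known or untested is meant among the compounds shown, and "the series" means these compounds.

Measured in a functional assay on DU-145 cells (Homo sapiens) for cytotoxicity, read by trypan blue exclusion, with a stated time of 96 h; on this read-out lower numbers stand for stronger inhibition and higher numbers for weaker inhibition:
- compound 1 `COC(=O)C(C)Nc1cc(NS(=O)(=O)/C=C/c2c(OC)cc(OC)cc2OC)ccc1OC` gives 100 nM
- compound 2 `COC(=O)C(Nc1cc(NS(=O)(=O)/C=C/c2c(OC)cc(OC)cc2OC)ccc1OC)c1ccc(Cl)cc1` gives 5000 nM
- compound 3 `COc1cc(OC)c(/C=C/S(=O)(=O)Nc2ccc(OC)c(NCC(=O)O)c2)c(OC)c1` gives 400 nM

For the measured compounds named here, of the three numbers, the one for compound 3 is the middle one, higher than that of compound 1 and lower than that of compound 2. The next structure, compound 4 `COc1cc(OC)c(/C=C/S(=O)(=O)Nc2ccc(OC)c(NC(C(=O)O)c3ccc(Cl)cc3)c2)c(OC)c1`, has 4-chlorophenyl in place of hydrogen on a saturated chain carbon bound to a carbonyl carbon and a nitrogen on an aromatic ring. The closest parallel is the same group replacing methyl at that carbon with methoxycarbonyl present, which gave a 50-fold higher number from compound 1 to compound 2 (1.70 log units; beyond the scatter) and so a large step toward weaker inhibition. The other two steps are less direct. The step of a 13-fold lower number from compound 2 to compound 3 (1.10 log units; beyond the scatter) combines loss of the 4-chlorophenyl with the change to carboxymethyl, and a 4.0-fold higher number from compound 1 to compound 3 (0.60 log units; beyond the scatter) is modest and involves no aryl group. Going by the values given here, no measured pair compares carboxyl with methoxycarbonyl while the 4-chlorophenyl stays in place, so the size of the effect on the carboxymethyl compound remains uncertain. A large step to a higher number is expected in this assay here. The estimated step is a 10-fold higher number from compound 3 to compound 4 (1.00 log units; beyond the scatter) (possibly smaller than the parallel one). Compound 4 is expected at 4000 nM (estimated range 1000 nM to 15000 nM).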

Compound 4, half-maximal inhibitory concentration: 75 nM
Compound 4: middle estimate off by 53-fold (1.73 log units), on the high side; measured number outside the range, below it.
By their numbers in this assay, from the lowest: compounds 4 and 1 (each within the scatter of the next); then compound 3; then compound 2.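

In this assay, 4-chlorophenyl on a saturated chain carbon bound to a carbonyl carbon and a nitrogen on an aromatic ring does not always go with weaker inhibition: with a free carboxyl group the change gives a 5.3-fold lower number from compound 3 to compound 4 (0.73 log units; beyond the scatter), against a 50-fold higher number from compound 1 to compound 2 (1.70 log units; beyond the scatter) with methoxycarbonyl present, so the direction of this change depends on the group carried on the same carbon. The pair that was missing, carboxyl against methoxycarbonyl with 4-chlorophenyl held in place, now reads as a 67-fold lower number from compound 2 to compound 4 (1.82 log units; beyond the scatter), a large difference from the ester methyl alone. On a nitrogen on an aromatic ring, carboxy(4-chlorophenyl)methyl and 1-(methoxycarbonyl)ethyl are not separated, at a 1.3-fold lower number from compound 1 to compound 4 (0.12 log units; within the scatter), and nothing measured here gives a reason for the reversal.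

The compounds shown leave open whether this dependence on carboxyl against methoxycarbonyl extends to other groups at this carbon, such as an unsubstituted phenyl or a longer alkyl chain. Also open, from the compounds shown here alone, is how a carboxamide in place of the carboxyl would read with 4-chlorophenyl retained.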